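From 4-Fluorobenzyl to 3-Chlorobenzyl: Estimating Compound 4

This account rests on a few compounds, and the source may have more. Where it says the series, first, only, none or still open, it means among the compounds named here.

Measured so far in an assay on isolated protein for inhibition of aldehyde dehydrogenase 1A1 (Homo sapiens), read by spectrophotometry, tested at 10 uM; a lower number here means less inhibition, a higher number more inhibition at the concentration tested (going by the name of the read-out):
compound 1 `CC(C)CCn1c(OC2CCN(C(=O)c3ccco3)CC2)nc2ccccc21`, 30.8%
compound 2 `O=C(C1CC1)N1CCN(Cc2nc3ccccc3n2Cc2ccc(F)cc2)CC1`, 32.7%
compound 3 `Cc1ccc(C(=O)N2CCN(Cc3nc4ccccc4n3Cc3cccc(C)c3)CC2)cc1`, 64.9%

Among these three numbers, compound 2 stands second highest. Its nearest neighbour is compound 1, whose number lies a little lower, but that gap sits within the usual scatter of this assay, so the two cannot be told apart. Compound 3 lies clearly higher, beyond the scatter, yet it differs from compound 2 in more than one place, so no single step can be read from that pair. For the measured compounds named here, no two measured compounds differ in only one place.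

Compound 4 `O=C(C1CC1)N1CCN(Cc2nc3ccccc3n2Cc2cccc(Cl)c2)CC1` differs from compound 2 in one place: 3-chlorophenyl in place of 4-fluorophenyl on a saturated chain carbon bound to an aromatic nitrogen. Going by the values given here, with no measured step of this kind to lean on, the expected change is modest, probably upward but quite possibly within the scatter. Compound 4 is therefore estimated at 40%, with a range from 22% to 60%. The step of a number 7.3 percentage points higher from compound 2 to compound 4 (within the scatter) that this estimate implies is an expectation, not a measurement.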

Compound 4, a percentage reported as inhibition, at one concentration (the size of the read-out at that concentration, not a potency): 71.6%
For compound 4 the middle estimate is 31.6 percentage points below the measured one, and the stated range ends below it.
By their numbers in this assay, from the lowest: compounds 1 and 2 (each within the scatter of the next); then compounds 3 and 4 (each within the scatter of the next).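

In this assay, for the compounds shown here, putting 3-chlorophenyl in place of 4-fluorophenyl on a saturated chain carbon bound to an aromatic nitrogen gives a number 38.9 percentage points higher from compound 2 to compound 4 (beyond the scatter), the first step in this set that can be read at a single place. It shows that this position is far from indifferent: changing this one group, with the rest of the molecule untouched, moves the read-out by a large amount, although both groups have the same heavy-atom count and neither has a hydrogen-bond donor or acceptor. Nothing shown here explains the rise.

Going by these compounds, the step changes both the halogen and its place on the ring, so the share of each remains unknown. On these data alone, whether 3-fluorophenyl or 4-chlorophenyl would give a number nearer compound 2 or compound 4 stays open, as does the result for plain phenyl.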